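The source may report more compounds than this note shows. Statements on the series, on what has been measured and on what is new or still open speak of the compounds shown alone.

Working notes on a small set of 1,4-diaryl triazoles tested for cytotoxicity on a breast cancer line.

Compound 1 `COc1ccc(-c2cn(-c3ccc(Oc4ccccc4)cc3)nn2)cc1` pairs a methoxyphenyl with a phenoxyphenyl on the shared core. In a functional assay on MDA-MB-231 cells (Homo sapiens) for cytotoxicity, read by MTT assay (a lower number here means a stronger inhibitor, a higher number a weaker inhibitor), compound 1 gives > 100 nM, and this entry is a limit of the assay rather than a number. Compound 2 `COc1ccc(-n2cc(-c3ccc(OC)c(OC)c3)nn2)c(OC)c1` carries a dimethoxyphenyl on each end of the core; in this assay compound 2 gives "not determined" (no result reported), so no number exists for it. Compound 3 `COc1ccc(-n2cc(-c3ccc(O)c(OC)c3)nn2)c(OC)c1` replaces one methyl on compound 2 by hydrogen; in this assay compound 3 likewise gives "not determined" (no result reported). Where compound 2 stands is therefore undefined: among the three entries one is a limit (the limit of > 100 nM in this assay, at which 1 of the 3 values shown sits) and the other two hold no value at all.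

Compound 4 `COc1ccc(-n2cc(-c3ccc(OC)c(O)c3)nn2)c(OC)c1` is the unmeasured neighbour of compound 2. The change is hydrogen in place of methyl on an oxygen on an aromatic ring. Among the compounds with values here, with no measured pair of this kind anywhere in the set, no size can be anchored; the expectation is a step of no particular direction and of a size within the scatter in this assay.

Because the only entry that resembles a number is the limit (the limit of > 100 nM in this assay, at which 1 of the 3 values shown sits), the estimate leans toward weak activity and a fair chance of another limit. Compound 4 is expected at about 3000 nM, with a range from 200 nM to 40000 nM.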

Compound 4, half-maximal inhibitory concentration: > 10000 nM
Compound 4: no number, only a limit; the forecaster's own chance of this, stated with the estimate: 55%; middle value at least 3.3-fold (0.52 log units) away from the limit.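

No step can be read from compound 2 to compound 4: compound 2 holds no number in this assay. In this assay compound 4 gives > 10000 nM, which is a limit of the assay and not a number. The compounds shown leave open what the change from methoxy to hydroxy does to the read-out in this assay.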